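The source may hold more compounds than are shown below. What is called first, only, known or untested is meant among the compounds shown, and "the series" means these compounds.

In an ADME assay on NIH3T3 cells (Mus musculus) for cytotoxicity, read by MTT assay, with a stated time of 24 h (a lower number here means a stronger inhibitor, a higher number a weaker inhibitor), three compounds sharing one core have been measured: compound 1 `COc1cc(/C=N/n2c(S)nnc2-c2cnccn2)cc(OC)c1OC` gives 169000 nM, compound 2 `Sc1nnc(-c2cnccn2)n1/N=C/c1ccc(Cl)cc1` gives 218000 nM, and compound 3 `Cc1ccc(/C=N/n2c(S)nnc2-c2cnccn2)cc1` gives 156000 nM. Compound 3 therefore stands within the usual scatter of both others, and the numbers do not separate the three. Compound 4 `Oc1ccc(/C=N/n2c(S)nnc2-c2cnccn2)cc1` has hydroxy in place of methyl on an aromatic carbon. Among the compounds with values here, only one measured step bears on this, a 1.4-fold lower number from compound 2 to compound 3 (0.15 log units; within the scatter), a different swap on the aromatic ring that stayed within the scatter. No change beyond the scatter is therefore expected in this assay, and no direction can be predicted. The estimated step is a 1.0-fold lower number from compound 3 to compound 4 (0.02 log units; within the scatter). Compound 4 is expected at 150000 nM, with an estimated range of 75000 nM to 300000 nM.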

Compound 4, half-maximal inhibitory concentration: 175000 nM
Beside the measured number, compound 4's estimate is 1.2-fold (0.07 log units) below it; the range from low to high includes it.
By their numbers in this assay, from the lowest: compounds 3, 1, 4 and 2 (each within the scatter of the next).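

In this assay, the swap from 4-methylphenyl to 4-hydroxyphenyl gives a 1.1-fold higher number from compound 3 to compound 4 (0.05 log units; within the scatter), and hydroxy in place of chloro gives a 1.2-fold lower number from compound 2 to compound 4 (0.10 log units; within the scatter). On an aromatic carbon para to a large group, then, adding a hydrogen-bond donor and acceptor does not separate compound 4 from compound 2 or compound 3. No measurement here offers an explanation for this result. On these data alone, whether an amine, a carboxylic acid or a longer chain at this position would move the number beyond the scatter remains open. So does the effect of changes elsewhere on the shared core.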